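Hydroxy in Place of Hydrogen on a Second Core

A few compounds are considered here, and "the series" means these few. Any claim that something is new, unique, unknown or untested is made for them only; others in the source may bear on it.

Compound 1 `O=C(/C=C/c1cccc(O)c1)/C=C/c1ccc(O)c(O)c1` and compound 2 `O=C(/C=C/c1ccc(O)c(O)c1)/C=C/c1cc(O)ccc1O` share one core; compound 3 `O=C(/C=C/c1cccc(O)c1)CC(=O)c1ccc(O)c(O)c1` and the as yet unmeasured compound 4 `O=C(/C=C/c1cc(O)ccc1O)CC(=O)c1ccc(O)c(O)c1` share another. The difference between the two cores is not broken down here.

In a physicochemical assay for solubility, using the shake flask method, with a stated time of 12 h (a lower number here means a less soluble compound, a higher number a more soluble compound), compound 1 gives 60000 nM, and compound 2 gives 123000 nM. The change from compound 1 to compound 2 is hydroxy in place of hydrogen on an aromatic carbon, and the step it made is a 2.1-fold higher number from compound 1 to compound 2 (0.31 log units; beyond the scatter). In this assay compound 3 gives 25000 nM, the lowest of the three numbers; its gaps to compound 1 and to compound 2 both lie beyond the usual scatter.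

Compound 4 differs from compound 3 by hydroxy in place of hydrogen on an aromatic carbon. The place lines of the two changes agree word for word, so this is the same change as from compound 1 to compound 2, now made on the other core; among the compounds shown it occurs twice in all. Within the data shown here, only one measured instance exists, so the expectation for compound 4 rests on that single earlier step, a 2.1-fold higher number from compound 1 to compound 2 (0.31 log units; beyond the scatter), with no second example on either core to test how far the size carries over. In this assay a step of about the same size is expected from compound 3 to compound 4, namely a 2.1-fold higher number from compound 3 to compound 4 (0.32 log units; beyond the scatter). Compound 4 is accordingly estimated at 52000 nM, with a plausible range from 30000 nM to 90000 nM.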

Compound 4, solubility: 47000 nM
The estimate for compound 4 lay 1.1-fold (0.04 log units) above the measured number; the measured number falls inside the stated range.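

In this assay, hydroxy in place of hydrogen on an aromatic carbon gives a 1.9-fold higher number from compound 3 to compound 4 (0.27 log units; within the scatter) on the core of compound 3 and a 2.1-fold higher number from compound 1 to compound 2 (0.31 log units; beyond the scatter) on the core of compound 1, so the size of the step carries over closely between these two cores. The new step lies within the usual scatter while the earlier one lies just beyond it, so the pair of compound 3 and compound 4 does not on its own separate this change from repeat variation, and what is supported is agreement in size with the earlier step, not a firmly established effect on the second core. Two instances on two cores make no rule for the series, and nothing measured here accounts for the size of either step.

The compounds shown leave open whether the same change keeps this size on any third core. They also leave open what an amine or a methoxy group would give in this assay at the same place, on an aromatic carbon ortho to a large group and para to a hydroxy group.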